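The compounds below may be only part of what the source reports. "The series", "measured", "known", "first", "only" and "open" are said of these compounds alone.

Working notes on the series. Of the compounds shown here, two have been measured so far, both in a functional assay on MIA PaCa-2 cells (Homo sapiens) for inhibition, read by MTT assay, with a stated time of 3 days; a higher number here means a weaker inhibitor, a lower number a stronger inhibitor. Compound 1 `CCN(CC)S(=O)(=O)c1ccc(S(=O)(=O)N2CCC[C@@H](C(=O)N3CCC(c4nc(C(C)C)no4)CC3)C2)cc1` is one of them; in this assay compound 1 returns only a limit, > 10000 nM. Compound 2 `CC(C)c1noc(N2CCN(C(=O)[C@@H]3CCCN(S(=O)(=O)c4ccc(S(=O)(=O)C5CCC5)cc4)C3)CC2)n1` is the other; in this assay compound 2 likewise returns only a limit, > 10000 nM. Where compound 2 stands is therefore not a number but the edge of what the measurement reports, and the one further value shown sits at that same edge (the limit of > 10000 nM in this assay, at which 2 of the 2 values shown sit). Within the data shown here, no pair of measured compounds differs in a single place, so no step between measured compounds exists to read a size or a direction from.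

Compound 3 `CC(C)c1noc(N2CCN(C(=O)[C@@H]3CCCN(S(=O)(=O)c4ccc(S(=O)(=O)NC5CC5)cc4)C3)CC2)n1` differs from compound 2 by cyclopropylamino in place of cyclobutyl on a sulfonyl sulfur. With both measured compounds at the limit, nothing in the numbers sets an expectation of a gain or a loss. The expected step is a step that the limit leaves unreadable from compound 2 to compound 3, none beyond the scatter. Compound 3 is accordingly estimated at 15000 nM, with a range from 5000 nM to 50000 nM, and is expected most likely to come back as a limit again.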

Compound 3, half-maximal inhibitory concentration: > 10000 nM
Compound 3: only a limit was reported; the forecaster's own chance of this, stated with the estimate: 85%; the middle value is on the limit's open side.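

No step can be read from compound 2 to compound 3, since both return only a limit in this assay and cyclopropylamino in place of cyclobutyl on a sulfonyl sulfur shows no readable size or direction: the limit of > 10000 nM in this assay, at which 3 of the 3 values shown sit. The compounds shown leave open whether any compound in this series gives a measurable half-maximal inhibitory concentration in this assay.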